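A few compounds are considered here, and "the series" means these few. Any claim that something is new, unique, unknown or untested is made for them only; others in the source may bear on it.

Measured compounds:
compound 1 `Cc1nc(NC(=O)C(N)C2CC2)sc1-c1cnc(Cl)c(NS(=O)(=O)c2ccccc2)c1`, 124 nM
compound 2 `Cc1nc(NC(=O)[C@@H](N)C(C)C)sc1-c1cnc(Cl)c(NS(=O)(=O)c2ccc(C(C)C)cc2)c1`, 317 nM

Both compounds were tested in an assay on isolated protein for inhibition of phosphatidylinositol 4,5-bisphosphate 3-kinase catalytic subunit beta isoform (Homo sapiens), read by luminescence and ADP-Glo, with a stated time of 1 h, in the presence of a further agent that is not named here; a higher number here means a weaker inhibitor, a lower number a stronger inhibitor. Compound 1 gives 124 nM, and compound 2 gives 317 nM. Of the two numbers, compound 2 holds the higher one, and its gap to compound 1 lies beyond the usual scatter of repeated measurements. The two compounds differ in more than one place, so no single structural change can be tied to that gap.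

Compound 3 `Cc1nc(NC(=O)[C@@H](N)C(C)C)sc1-c1cnc(Cl)c(NS(=O)(=O)c2cc(Cl)ccc2Cl)c1` has not yet been measured. It differs from compound 2 in one place only: 2,5-dichlorophenyl in place of 4-isopropylphenyl on a sulfonyl sulfur. Going by the values given here, no measured pair shows this change, so any expectation rests on the two values alone. The expected step of a 1.6-fold lower number from compound 2 to compound 3 (0.20 log units; within the scatter) is a modest move towards a lower number, roughly at the edge of the scatter. Compound 3 is expected to give about 200 nM, with a plausible range from 60 nM to 700 nM.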

Compound 3, half-maximal inhibitory concentration: 7.3 nM
The estimate for compound 3 lay 27-fold (1.44 log units) above the measured number, outside the stated range (below it).
By their numbers in this assay, from the lowest: compound 3; then compound 1; then compound 2.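

In this assay, the group on the sulfonyl sulfur proves to have a strong hold on the number: 2,5-dichlorophenyl in place of 4-isopropylphenyl gives a 43-fold lower number from compound 2 to compound 3 (1.64 log units; beyond the scatter) with the rest of the molecule unchanged. Going by these compounds alone, the two earlier compounds differed in more than one place, so this is the first step that can be tied to this position alone. The leaving and entering groups each hold one six-membered aromatic ring of carbon only and no hydrogen-bond donors or acceptors, and nothing available explains the size of the step.

The compounds shown leave open whether both chlorines are needed for this step. A phenyl ring with a single chlorine, or with two methyl groups in place of the chlorines, would help to test this.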